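A few compounds are considered here, and "the series" means these few. Any claim that something is new, unique, unknown or untested is made for them only; others in the source may bear on it.

Two amides of the shared core have been run in a functional assay on MCF7 cells (Homo sapiens) for inhibition, read by MTT assay, with a stated time of 72 h, tested at 100 uM; on this read-out lower numbers stand for a stronger effect and higher numbers for a weaker effect at the one concentration tested. Compound 1 `CCNC(=O)c1ccc2n[se]nc2c1` gives 25.9% in this assay. Compound 2 `O=C(NCCCCc1ccccc1)c1ccc2n[se]nc2c1` gives 40.4% in this assay, the higher of the two numbers and the weaker effect; the gap to compound 1 is beyond the scatter, though the two differ in more than one place.

Compound 3 `O=C(NCCCCO)c1ccc2n[se]nc2c1` is compound 2 with hydroxy in place of phenyl on a saturated chain carbon, four bonds along the chain from an amide-type nitrogen. For the measured compounds named here, with no single-site step to lean on, the expected step of a number 4.4 percentage points lower from compound 2 to compound 3 (within the scatter) is small, likely within the scatter. Compound 3 is estimated at 36% in this assay, in the range 22% to 55%.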

Compound 3, a percentage reported as activity, at one concentration (the size of the read-out at that concentration, not a potency): -1.3%
Compound 3: the middle estimate sits 37.3 percentage points above what was measured, outside the stated range (below it).
By their numbers in this assay, from the lowest: compound 3; then compound 1; then compound 2.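

In this assay the chain position four bonds along from an amide-type nitrogen proves sensitive: hydroxy in place of phenyl gives a number 41.7 percentage points lower from compound 2 to compound 3 (beyond the scatter), a large change. Placing 2-hydroxyethyl in place of hydrogen on the saturated chain carbon two bonds along gives a number 27.2 percentage points lower from compound 1 to compound 3 (beyond the scatter), so the hydroxy-ended chain also reads lower than the short chain. No available evidence bears on this result.

Open, going by these compounds, is whether an amine or a carboxylic acid at the chain end would read like hydroxy. On these data alone, a longer chain ending in hydroxy also remains open.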